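Swapping an ortho fluoro for trifluoromethyl on compound 3

The source may hold more compounds than are shown below. What is called first, only, known or untested is meant among the compounds shown, and "the series" means these compounds.

Measured so far:
compound 1 `Cc1nc(-c2ccsc2)sc1COc1ccc2c(c1)OCC2CC(=O)O` gives 56.5%
compound 2 `Cc1nc(-c2cccc(Cl)c2)sc1COc1ccc2c(c1)OCC2CC(=O)O` gives 43%
compound 3 `Cc1nc(-c2ccccc2F)sc1COc1ccc2c(c1)OCC2CC(=O)O` gives 25.8%

In a functional assay on CHO cells for agonist activity at Free fatty acid receptor 1 (Homo sapiens), read by FLIPR and calcium flux, tested at 100 nM (on this read-out lower numbers stand for a weaker effect and higher numbers for a stronger effect at the one concentration tested), compound 3 stands lowest of the three, a number 30.7 percentage points lower from compound 1 to compound 3 (beyond the scatter) and a number 17.2 percentage points lower from compound 2 to compound 3 (beyond the scatter) both lying beyond the scatter. Compound 4 `Cc1nc(-c2ccccc2C(F)(F)F)sc1COc1ccc2c(c1)OCC2CC(=O)O` differs from compound 3 by trifluoromethyl in place of fluoro on an aromatic carbon, on an aromatic carbon of a six-membered aromatic ring of carbon only. Going by the values given here, no measured step changes a group on this ring carbon; the steps seen concern the whole aromatic group, so they bear only loosely on this one. The expectation is therefore a small shift, not clearly beyond the scatter, with compound 4 estimated at 22%, range 8% to 40%, meaning an expected step of a number 3.8 percentage points lower from compound 3 to compound 4 (within the scatter).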

Compound 4, a percentage reported as activity, at one concentration (the size of the read-out at that concentration, not a potency): 7.76%
For compound 4 the middle estimate is 14.2 percentage points above the measured one; the measured number lies below the stated range.
By their numbers in this assay, from the lowest: compound 4; then compound 3; then compound 2; then compound 1.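

Putting trifluoromethyl in place of fluoro on the same ring carbon is a real change in this assay: there is a number 18 percentage points lower from compound 3 to compound 4 (beyond the scatter), so the read-out is sensitive to the group at this one spot. The 2-(trifluoromethyl)phenyl group also falls well short of the other aromatic groups, with a number 35.2 percentage points lower from compound 2 to compound 4 (beyond the scatter) and a number 48.7 percentage points lower from compound 1 to compound 4 (beyond the scatter), which leaves compound 4 lowest of the four. Nothing available explains this drop.

As far as these compounds go, whether a methoxy group or an amine on this ring carbon would read closer to fluoro or to trifluoromethyl stays open. So does whether trifluoromethyl would give the same drop on another carbon of this ring.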